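This account rests on a few compounds, and the source may have more. Where it says the series, first, only, none or still open, it means among the compounds named here.

Measured so far:
compound 1, `CCCCCCCCCCCCCCC1(C(=O)OCC(O)CO)CO1`, 5 mg/kg
compound 2, `CCCCCCCCCCCCCCC1(C(=O)OCCCC)CO1`, 1.5 mg/kg
compound 3, `CCCCCCCCCCCCCCC1(C(=O)OC)CO1`, 4 mg/kg

These three compounds share one core and differ only in the group on the saturated chain carbon bound to the oxygen next to the carbonyl group. In a functional assay on the whole organism with Rattus norvegicus as the target, in the glucose tolerance test (a lower number here means that less compound is needed, a higher number that more compound is needed for the effect), compound 3 gives 4 mg/kg, the second highest of the three numbers; its nearest neighbour lies within the scatter, a 1.3-fold lower number from compound 1 to compound 3 (0.10 log units; within the scatter), while the other is further off, a 2.7-fold higher number from compound 2 to compound 3 (0.43 log units; beyond the scatter).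

Compound 4, `CCCCCCCCCCCCCCC1(C(=O)N(C)C)CO1`, has not yet been measured. It differs from compound 3 at the carbonyl carbon: dimethylamino in place of methoxy on a carbonyl carbon. Among the compounds with values here, none of the measured steps touch this place. The steps of a 3.3-fold lower number from compound 1 to compound 2 (0.52 log units; beyond the scatter), a 2.7-fold higher number from compound 2 to compound 3 (0.43 log units; beyond the scatter) and a 1.3-fold lower number from compound 1 to compound 3 (0.10 log units; within the scatter) all swap the group on the oxygen and leave the carbonyl carbon as it is, so they give no direct guide to exchanging methoxy for dimethylamino. With nothing to lean on beyond the modest span of the three numbers, no step beyond the scatter is expected, and compound 4 is expected to show no change at the digits printed from compound 3 to compound 4 (within the scatter). The estimate for compound 4 is 4 mg/kg, within a range from 1.5 mg/kg to 12 mg/kg.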

Compound 4, minimum effective dose: 25 mg/kg
The estimate for compound 4 lay 6.3-fold (0.80 log units) below the measured number; the whole stated range lies below it.
By their numbers in this assay, from the lowest: compound 2; then compounds 3 and 1 (each within the scatter of the next); then compound 4.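

In this assay, the carbonyl carbon proves to be a place where a single exchange matters: dimethylamino in place of methoxy gives a 6.3-fold higher number from compound 3 to compound 4 (0.80 log units; beyond the scatter). Within the data shown here, the same exchange measured against the other two groups gives a 17-fold higher number from compound 2 to compound 4 (1.22 log units; beyond the scatter) and a 5.0-fold higher number from compound 1 to compound 4 (0.70 log units; beyond the scatter), so in this set dimethylamino calls for more compound than methoxy, butoxy or 2,3-dihydroxypropoxy, whereas the earlier comparisons only varied the group on the oxygen. No measurement shown here bears on the reason for this shift.

The compounds shown leave open whether the change depends on the nitrogen itself or on the groups it carries. Methylamino, diethylamino or butylamino on the same carbonyl carbon, or a carboxylic acid there, would help to separate these possibilities.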